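A few compounds are considered here, and "the series" means these few. Any claim that something is new, unique, unknown or untested is made for them only; others in the source may bear on it.

Measured so far:
compound 1 `COc1ccc(-c2nc3sc(Cc4ccccc4)nn3c2SC#N)cc1` gives 7900 nM
compound 2 `O=Cc1c(-c2ccc([N+](=O)[O-])cc2)nc2sc(Cc3ccccc3)nn12` gives 3700 nM

In a functional assay on cells (Cancer cell lines, Homo sapiens) for inhibition (on this read-out lower numbers stand for stronger inhibition of growth and higher numbers for weaker inhibition of growth), compound 1 stands at 7900 nM, the higher of the two numbers. Compound 2 sits at 3700 nM, a gap beyond the usual scatter. Compound 3 `N#CSc1c(-c2ccccc2)nc2sc(Cc3ccccc3)nn12` has not been measured. Against compound 1 it differs by hydrogen in place of methoxy on an aromatic carbon. Among the measured compounds shown here, no measured pair shows this change, so no step for it can be drawn from the data. The expectation is that the step of a 1.0-fold higher number from compound 1 to compound 3 (0.01 log units; within the scatter) stays within the scatter, with no direction favoured. Compound 3 is therefore estimated at 8000 nM, in a range from 3000 nM to 20000 nM.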

Compound 3, concentration for 50% growth inhibition: 15100 nM
Estimate against measurement, compound 3: 1.9-fold (0.28 log units) below; low and high end bracket the measured number.
By their numbers in this assay, from the lowest: compound 2; then compounds 1 and 3 (each within the scatter of the next).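

In this assay, among the compounds shown here, the change from 4-methoxyphenyl to phenyl gives a 1.9-fold higher number from compound 1 to compound 3 (0.28 log units; within the scatter), the first step that can be read at this position. In this single pair, hydrogen in place of methoxy on the aromatic carbon para to a large group gives no step beyond the scatter, so the methoxy is not shown to matter here. Nothing measured on these compounds bears on this result.

As far as these compounds go, whether an amine or a carboxylic acid at this same position would give a step beyond the scatter remains open. The same holds for a longer alkoxy chain.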